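From methoxymethyl to ethoxymethyl on the shared core

This account rests on a few compounds, and the source may have more. Where it says the series, first, only, none or still open, it means among the compounds named here.

Measured in a physicochemical assay for solubility, in phosphate buffer, measured as kinetic solubility; on this read-out lower numbers stand for lower solubility and higher numbers for higher solubility:
compound 1 `CCc1nn2c(-c3c(OC)cc(C)cc3OC)cccc2c1N(CC1CCOCC1)CC1CC1` gives 1600 nM
compound 2 `CCc1nn2c(-c3c(OC)cccc3OC)cccc2c1N(CC1CCOCC1)CC1CC1` gives 3300 nM
compound 3 `CCc1nn2c(-c3c(OC)cc(COC)cc3OC)cccc2c1N(CC1CCOCC1)CC1CC1` gives 4800 nM

In this assay compound 3 stands level with compound 2 within the scatter (a 1.5-fold higher number from compound 2 to compound 3 (0.16 log units; within the scatter)) and clearly apart from compound 1 (a 3.0-fold higher number from compound 1 to compound 3 (0.48 log units; beyond the scatter)). Compound 4 `CCOCc1cc(OC)c(-c2cccc3c(N(CC4CCOCC4)CC4CC4)c(CC)nn23)c(OC)c1` is still unmeasured and carries ethoxymethyl where compound 3 carries methoxymethyl (methyl in place of hydrogen on a saturated chain carbon bound to an oxygen on a saturated carbon). Among the compounds with values here, no measured step makes this exact change, and the nearest evidence pulls two ways. Within the data shown here, the one step that removes a methyl does so at a different place, on an aromatic carbon (a 2.1-fold higher number from compound 1 to compound 2 (0.31 log units; beyond the scatter)), and read in reverse it would hint at a small fall. The step that extends the group on compound 1 (a 3.0-fold higher number from compound 1 to compound 3 (0.48 log units; beyond the scatter)) instead went up. Both are modest, so they offer no firm direction, only a slight downward lean. The estimated step in this assay is a 1.3-fold lower number from compound 3 to compound 4 (0.10 log units; within the scatter) and none beyond the scatter is expected. Compound 4 is expected at about 3800 nM with an estimated range of 1700 nM to 8000 nM in this read-out.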

Compound 4, solubility: 1400 nM
Beside the measured number, compound 4's estimate is 2.7-fold (0.43 log units) above it, and the stated range ends above it.
By their numbers in this assay, from the lowest: compounds 4 and 1 (each within the scatter of the next); then compounds 2 and 3 (each within the scatter of the next).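

In this assay, the change from methoxymethyl to ethoxymethyl is not silent at this position: one added methyl on a saturated chain carbon bound to an oxygen gives a step beyond the scatter (a 3.4-fold lower number from compound 3 to compound 4 (0.54 log units; beyond the scatter)). The step from the hydrogen-bearing compound is also beyond the scatter (a 2.4-fold lower number from compound 2 to compound 4 (0.37 log units; beyond the scatter)), so an ether chain at this place does not by itself hold the number up, while the comparison with the methyl-bearing compound stays within the scatter (a 1.1-fold lower number from compound 1 to compound 4 (0.06 log units; within the scatter)). Nothing available explains why so small a change gives a step of this size.

Open, on these data alone, is whether hydroxymethyl or a longer chain such as propoxymethyl would extend this trend or break it. Equally open, as far as these compounds go, is how an amine such as dimethylaminomethyl would read at this place.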